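Chlorine in Place of Methoxy on the Sulfonyl Aryl

The compounds below may be only part of what the source reports. "The series", "measured", "known", "first", "only" and "open" are said of these compounds alone.

Three compounds share a sulfonamide attached to a common core. Compound 1 `O=S(=O)(Nc1ccc(-c2nc3ccccc3o2)cc1)c1cccc(Cl)c1` and compound 2 `O=S(=O)(Nc1ccc(-c2nc3ccccc3o2)cc1)c1ccccc1C(F)(F)F` carry the sulfonamide nitrogen on a phenyl that hangs from the core, while compound 3 `COc1cccc(S(=O)(=O)Nc2ccc3oc(-c4ccccc4)nc3c2)c1` carries it on the core itself. In an ADME assay on HEK293 cells (Homo sapiens) for cytotoxicity, read by resazurin assay, with a stated time of 48 h (on this read-out higher numbers stand for lower toxicity in this test and lower numbers for higher toxicity in this test), compound 1 reaches only a limit of the test, > 100000 nM. Compound 2 likewise stops at a limit, > 100000 nM. Among the measured compounds shown here, compound 3 is the single member of the set with a number: in this assay compound 3 gives 63000 nM. Two of the three values thus sit at the limit of > 100000 nM in this assay, at which 2 of the 3 values shown sit, and compound 3 alone stands with a measured figure in this low-toxicity region.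

Compound 4 `O=S(=O)(Nc1ccc2oc(-c3ccccc3)nc2c1)c1ccc(Cl)cc1` is the untested partner of compound 3. The change is modest: 4-chlorophenyl in place of 3-methoxyphenyl on a sulfonyl sulfur. For the measured compounds named here, no measured pair shows what this swap does here, so the direction in this assay rests on weak ground; compound 1, whose sulfonyl aryl also bears a chlorine, reached its limit at > 100000 nM. The step of a 1.3-fold higher number from compound 3 to compound 4 (0.10 log units; within the scatter) is expected to stay within the usual scatter, leaning if anything toward lower toxicity. Compound 4 is estimated at 80000 nM, within 40000 nM to 200000 nM, with a fair chance that only a limit is reported.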

Compound 4, half-maximal cytotoxic concentration: 65000 nM
Compound 4: middle estimate off by 1.2-fold (0.09 log units), on the high side, within the range that was stated.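

Among the compounds shown here, the first measured pair at this position gives, in this assay, a 1.0-fold higher number from compound 3 to compound 4 (0.01 log units; within the scatter), for 4-chlorophenyl in place of 3-methoxyphenyl on a sulfonyl sulfur. The earlier compounds shown here offered no such pair; this one shows that the two aryl groups cannot be told apart on this read-out, so the swap leaves the toxicity reading of this series where it stood. The sulfonyl aryl of this core thus accepts a chlorine in place of a methoxy without a readable step, although this single pair cannot separate the exchange of substituent from the different placing in the two group names, and the two compounds with the sulfonamide on a hanging phenyl still offer no number, only this: the limit of > 100000 nM in this assay, at which 2 of the 4 values shown sit.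

From the compounds shown here alone, whether an amine or a carboxylic acid on this aryl, or a longer alkyl chain in place of the aryl itself, would also leave the reading unmoved stays open. The compounds shown also leave open whether the same swap would read alike on the core of compound 1.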